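A Chloro Substituent Added to an Aryl Ether Acid

This account rests on a few compounds, and the source may have more. Where it says the series, first, only, none or still open, it means among the compounds named here.

Of the compounds shown here, two have numbers so far. Compound 1 `Cc1c(OCCCCOc2ccc(C(=O)O)cc2)ccc(C(=O)CC2CCCC2)c1O` gives 824 nM in an assay on HEK293 cells for positive allosteric modulation of metabotropic glutamate receptor 2 (Rattus norvegicus), read by thallium flux, with a stated time of 2.5 min (on this read-out higher numbers stand for an effect only at larger amounts of compound and lower numbers for an effect already at smaller amounts), the higher of the two. Compound 2 `CCCC(=O)c1ccc(OCCCCOc2cccc(C(=O)O)c2C)c(C)c1O` gives 52 nM in this assay, a gap well beyond the usual scatter. Compound 3 `Cc1c(OCCCCOc2ccc(C(=O)O)cc2Cl)ccc(C(=O)CC2CCCC2)c1O` has not been measured. It differs from compound 1 by chloro in place of hydrogen on an aromatic carbon, ortho to a large group and meta to a carboxy group. Among the measured compounds shown here, no measured pair shows this exact change, so the size of the step is uncertain; a modest move toward a lower number is expected, a 1.6-fold lower number from compound 1 to compound 3 (0.22 log units; within the scatter). Compound 3 is estimated at 500 nM, with a range from 150 nM to 1600 nM.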

Compound 3, half-maximal effective concentration: 237 nM
The estimate for compound 3 lay 2.1-fold (0.32 log units) above the measured number; the range from low to high includes it.
By their numbers in this assay, from the lowest: compound 2; then compound 3; then compound 1.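

Chloro on this aromatic carbon, ortho to a large group and meta to a carboxy group, gives a 3.5-fold lower number from compound 1 to compound 3 (0.54 log units; beyond the scatter) in this assay and adds one heavy atom. Among the compounds shown here, this is the first single-place change with a measured size, since the two earlier compounds differ in more than one place. No measurement here accounts for the size of this step.
On these data alone, it remains open whether fluoro, methoxy or an amine on the same carbon would give a similar step. As far as these compounds go, the effect of chloro in the setting of compound 2 also remains open.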